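Notes on compound 4: trifluoromethyl in place of fluoro

This account rests on a few compounds, and the source may have more. Where it says the series, first, only, none or still open, it means among the compounds named here.

Measured so far in a functional assay on BGC-823 cells (Homo sapiens) for antiproliferative activity, read by MTT assay, tested at 1 uM; a higher number here means a stronger effect of the compound at the concentration tested, a lower number a weaker effect:
compound 1 `COc1cc(C(=O)N/N=C/c2ccc(F)c(F)c2)cc(OC)c1OC`: 33.1%
compound 2 `COc1cc(C2=NN(C(C)=O)C(c3c(Cl)cccc3Cl)O2)cc(OC)c1OC`: -1.4%
compound 3 `COc1cc(C(=O)N/N=C/c2cccc(F)c2)cc(OC)c1OC`: 13.6%

Compound 3 stands second highest of the three numbers. Its nearest neighbour is compound 2, which lies lower by a gap beyond the scatter; compound 2 differs from compound 3 in more than one place, so that gap carries no single structural reading. Among the compounds with values here, compound 1 lies higher than compound 3, also beyond the scatter, and this pair is the only one-place step: a number 19.5 percentage points lower from compound 1 to compound 3 (beyond the scatter). Within the data shown here, it shows that what sits on this aromatic carbon is felt in this assay, but it says nothing about trifluoromethyl itself, which no measured compound carries.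

Compound 4 `COc1cc(C(=O)N/N=C/c2cccc(C(F)(F)F)c2)cc(OC)c1OC` differs from compound 3 by trifluoromethyl in place of fluoro on an aromatic carbon. Among the measured compounds shown here, no measured step covers this exchange. For the measured compounds named here, the only related step, that from compound 1 to compound 3, concerns loss of fluoro, not its replacement by a larger group, so it sets no direction here. The expectation is a number near that of compound 3, with the step of a number 4.4 percentage points higher from compound 3 to compound 4 (within the scatter) not clearly beyond the scatter and a wide range allowed. Compound 4 is estimated at 18%, between 0% and 38%.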

Compound 4, a percentage reported as inhibition, at one concentration (the size of the read-out at that concentration, not a potency): 17.7%
Beside the measured number, compound 4's estimate is 0.3 percentage points above it; the measured number falls inside the stated range.
By their numbers in this assay, from the lowest: compound 2; then compounds 3 and 4 (each within the scatter of the next); then compound 1.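

In this assay the exchange of fluoro for trifluoromethyl on this aromatic carbon, meta to a large group, gives a step within the scatter (a number 4.1 percentage points higher from compound 3 to compound 4 (within the scatter)), so going from 1 heavy atom to 4 heavy atoms here leaves the read-out without a distinguishable change at the concentration tested. Within the data shown here, this is the first reading of a group larger than fluoro at this place, and it shows that trifluoromethyl can stand there without a loss beyond the scatter, though also without a gain. Among these compounds, the one step beyond the scatter (a number 19.5 percentage points lower from compound 1 to compound 3 (beyond the scatter)) is a different exchange, hydrogen in place of fluoro, and the new step neither extends it nor bears on it; no measurement at hand accounts for either step.

Still open, as far as these compounds go, is whether a group of another kind on this aromatic carbon, such as a nitrile, an amine or a carboxylic acid, would move the number beyond the scatter. Also open, from the compounds shown here alone, is whether trifluoromethyl would read the same way on the ring of compound 1, where a second fluoro is present.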